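The source may hold more compounds than are shown below. What is called first, only, known or untested is meant among the compounds shown, and "the series" means these compounds.

Of the compounds shown here, three have been measured so far in a functional assay on HT-29 cells (Homo sapiens) for cytotoxicity, read by MTT assay, with a stated time of 72 h; a higher number here means a weaker inhibitor of growth, a lower number a stronger inhibitor of growth. Compound 1 `CS/C(=N\C(=O)c1cc2ccccc2s1)NC(=O)c1cc2ccccc2s1` gives 88200 nM in this assay, a weak effect on growth. For compound 2 `O=C(/N=C(/NC(=O)c1cc(-c2ccccc2)nc2ccccc12)[Se]Cc1ccccc1)c1cc(-c2ccccc2)nc2ccccc12` this assay returns only a limit of the method, > 100000 nM, and not a number. For compound 3 `C[Se]/C(=N\C(=O)c1ccno1)NC(=O)c1ccno1` this assay likewise returns only a limit, > 100000 nM. Within the data shown here, compound 2 therefore stands where most of the set stands, at the limit of > 100000 nM in this assay, at which 2 of the 3 values shown sit, so no step between measured compounds can be counted and nothing beyond the usual scatter can be read from it.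

Compound 4 `CS/C(=N\C(=O)c1cc(-c2ccccc2)nc2ccccc12)NC(=O)c1cc(-c2ccccc2)nc2ccccc12` keeps the core of compound 2 and changes one place: a group of 2 heavy atoms (1 carbon, 1 sulfur; no ring) in place of a group of 8 heavy atoms (7 carbon, 1 selenium; one six-membered aromatic ring of carbon only), on a carbon with a double bond to nitrogen. Compound 1 carries the same methylsulfanyl group on the same kind of carbon, and in this assay compound 1 gives 88200 nM. With only that to go on, the step from compound 2 to compound 4 in this assay is expected to be none beyond the scatter, an at least 1.1-fold lower number from compound 2 to compound 4 (0.04 log units; that floor lies within the scatter). Compound 4 is accordingly estimated at 90000 nM, with a range from 40000 nM to 200000 nM. For compound 4 it is about as likely as not that this assay again reports only a limit.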

Compound 4, concentration for total growth inhibition: > 100000 nM
Compound 4: a limit, no number; the forecaster's own chance of this, stated with the estimate: 50%; middle value at least 1.1-fold (0.04 log units) away from the limit.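

Compound 2 and compound 4 both return only a limit and not a number, so no step between them can be read: the limit of > 100000 nM in this assay, at which 3 of the 4 values shown sit.

The compounds shown leave open whether methylsulfanyl in place of the selenium-bearing group on this carbon changes growth inhibition at all in this assay.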